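This account rests on a few compounds, and the source may have more. Where it says the series, first, only, none or still open, it means among the compounds named here.

Compound 2 `COC(=O)C1=C(C)NC(C)=C(C(=O)OC)C1c1c(-c2ccccn2)nc2sc(C)cn12` gives 2810 nM in a functional assay on ileum (Cavia porcellus) for inhibition (a higher number here means a weaker inhibitor, a lower number a stronger inhibitor), the second highest of the three numbers measured. Its nearest neighbour is compound 3 `COC(=O)C1=C(C)NC(C)=C(C(=O)OC)C1c1c(-c2cccnc2)nc2sccn12`, which gives 3550 nM in this assay, a gap that lies within the scatter of repeated measurements. Far from both stands compound 1 `COC(=O)C1=C(C)NC(C)=C(C(=O)OC)C1c1c(-c2ccsc2)nc2sccn12`, which gives 2.3 nM in this assay. Among the measured compounds shown here, the only single-place step among the measured compounds is a 1500-fold higher number from compound 1 to compound 3 (3.19 log units; beyond the scatter), which shows how much a pyridyl group in place of a thienyl group can cost.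

Compound 4 `COC(=O)C1=C(C)NC(C)=C(C(=O)OC)C1c1c(-c2ccncc2)nc2sc(C)cn12` differs from compound 2 in one place: pyridin-4-yl in place of pyridin-2-yl on an aromatic carbon. For the measured compounds named here, no measured step covers this exchange of one pyridyl isomer for another. What the numbers show is that compound 2 and compound 3, each carrying a pyridyl group, sit close together at the weak end, and compound 4 keeps a pyridyl group. A step of a 1.1-fold higher number from compound 2 to compound 4 (0.03 log units; within the scatter) is therefore expected, that is, none beyond the scatter. Compound 4 is estimated to give 3000 nM in this assay, within a range from 700 nM to 13000 nM.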

Compound 4, half-maximal inhibitory concentration: 9690 nM
Estimate against measurement, compound 4: 3.2-fold (0.51 log units) below; measured number inside the range.
By their numbers in this assay, from the lowest: compound 1; then compounds 2 and 3 (each within the scatter of the next); then compound 4.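

The two groups share the same atoms and the same counts. The exchange of pyridin-2-yl for pyridin-4-yl changes only how the pyridyl group is joined, and that alone gives a 3.4-fold higher number from compound 2 to compound 4 (0.54 log units; beyond the scatter) in this assay. This position therefore responds to which pyridyl isomer it carries, not only to whether it carries a pyridyl or a thienyl group, although this step is much smaller than a 1500-fold higher number from compound 1 to compound 3 (3.19 log units; beyond the scatter). Nothing measured here explains the difference between the two isomers.

As far as these compounds go, it remains open whether pyridin-3-yl on the core of compound 2 would fall nearer to compound 2 or to compound 4, and whether thiophen-3-yl would give a similarly low number on that core. From the compounds shown here alone, how a phenyl group, which has no ring nitrogen, would behave at this position also remains open.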